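Methylating the amide nitrogen of a dimethoxyindane acetamide

The compounds below may be only part of what the source reports. "The series", "measured", "known", "first", "only" and "open" are said of these compounds alone.

Compound 1, with the structure `COc1cc2c(cc1OC)C(CC(=O)O)CC2`, and compound 2, with the structure `COc1cc2c(cc1OC)C(CC(N)=O)CC2`, share one core and differ only at the carbonyl group. In a functional assay on the whole organism (strain Wistar) for inhibition, with Rattus norvegicus as the target, read by paw edema, with stated times of 60 min and 4 h, at a dose of 100 mg/kg by the oral route (on this read-out higher numbers stand for more inhibition at the one dose given (going by the name of the read-out) and lower numbers for less inhibition), compound 1 gives 23.9%. In the same test compound 2 gives 31.3%. Within the data shown here, the one step measured so far, a number 7.4 percentage points higher from compound 1 to compound 2 (within the scatter), stays within the usual scatter, so the two compounds cannot be told apart on these numbers; compound 2 merely carries the larger of the two figures.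

Compound 3, with the structure `CNC(=O)CC1CCc2cc(OC)c(OC)cc21`, is not yet measured. It differs from compound 2 by methyl in place of hydrogen on an amide-type nitrogen. Among the measured compounds shown here, no measured step touches the amide nitrogen itself; the only step known changes the group on the carbonyl carbon, and that step, a number 7.4 percentage points higher from compound 1 to compound 2 (within the scatter), was small. With nothing pointing to a larger effect, the expectation for compound 3 in this assay is a step of a number 1.3 percentage points lower from compound 2 to compound 3 (within the scatter), that is, no change beyond the scatter. Compound 3 is therefore estimated at 30%, with a range from 14% to 46%.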

Compound 3, a percentage reported as inhibition, in the whole organism at one dose (the size of the read-out at that dose, not a potency): 29.7%
Compound 3: middle estimate off by 0.3 percentage points, on the high side, and the stated range covers the measured number.
By their numbers in this assay, from the lowest: compounds 1, 3 and 2 (each within the scatter of the next).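

In this assay, among these compounds, the amide nitrogen is changed for the first time, and methyl in place of the amide hydrogen gives a number 1.6 percentage points lower from compound 2 to compound 3 (within the scatter) on this read-out. This adds a second kind of change to the one seen before: at one oral dose, the amide nitrogen of this series can carry methyl instead of hydrogen with no difference that can be told from the scatter. The change at the carbonyl carbon from hydroxy to methylamino gives a number 5.8 percentage points higher from compound 1 to compound 3 (within the scatter) and also stays within the scatter, so neither this replacement of hydroxy nor the one by amino separates the compounds, and no measurement of another kind is available to say what lies behind these results.

As far as these compounds go, what a second methyl on the same nitrogen, an ethyl group or a longer chain would do remains open, since one added carbon says little about larger groups at this place. Also open, from the compounds shown here alone, is whether a phenyl group on that nitrogen, or an amine in place of the whole carbamoyl group, would give a number beyond the scatter.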